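A few compounds are considered here, and "the series" means these few. Any claim that something is new, unique, unknown or untested is made for them only; others in the source may bear on it.

Measured so far in a functional assay for inhibition, with Rattus norvegicus as the target; a lower number here means a stronger inhibitor, a higher number a weaker inhibitor:
- compound 1 `CC(C)(C)/N=c1\c(O)c(O)\c1=N/Cc1cccc(F)c1`: 2400 nM
- compound 2 `CC(C)(C)/N=c1\c(O)c(O)\c1=N/Cc1ccccc1`: 3400 nM
- compound 3 `CC(C)(C)/N=c1\c(O)c(O)\c1=N/Cc1ccncc1`: 3000 nM

Compound 2 is the reference point for the next step, and this assay does not separate it from its two measured neighbours. Both of its steps, a 1.4-fold higher number from compound 1 to compound 2 (0.15 log units; within the scatter) and a 1.1-fold lower number from compound 2 to compound 3 (0.05 log units; within the scatter), lie within the scatter.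

The unmeasured compound 4 `CC(C)(C)/N=c1\c(O)c(O)\c1=N/Cc1ccccc1F` differs from compound 2 as follows: fluoro in place of hydrogen on an aromatic carbon. The new fluoro of compound 4 sits ortho to a large group.

For the measured compounds named here, two measured steps bear on this change. The closer one is a 1.4-fold higher number from compound 1 to compound 2 (0.15 log units; within the scatter), which exchanges fluoro for hydrogen on an aromatic carbon, though at a different place on the ring, so it is read in reverse here. The other is a 1.1-fold lower number from compound 2 to compound 3 (0.05 log units; within the scatter), a replacement of phenyl by pyridin-4-yl, which also stays within the scatter. Going by the values given here, no measured compound carries fluoro at the place it occupies in compound 4, so this reading is an extrapolation. On this evidence, no step beyond the scatter is expected in this assay.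

The estimated 1.2-fold lower number from compound 2 to compound 4 (0.08 log units; within the scatter) is therefore small, with no firm direction expected. For compound 4 the expected value is 2800 nM, with an estimated range from 1500 nM to 5200 nM.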

Compound 4, half-maximal inhibitory concentration: 2100 nM
Compound 4: the middle estimate sits 1.3-fold (0.12 log units) above what was measured; the range from low to high includes it.
By their numbers in this assay, from the lowest: compounds 4, 1, 3 and 2 (each within the scatter of the next).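

In this assay, fluoro on an aromatic carbon ortho to a large group gives a 1.6-fold lower number from compound 2 to compound 4 (0.21 log units; within the scatter), so this position now has a direct reading, and the change does not separate compound 4 from compound 2. Fluoro at the other measured place on the ring gives the same kind of reading, with a 1.4-fold higher number from compound 1 to compound 2 (0.15 log units; within the scatter), so neither fluoro placement shown produces a step beyond the scatter in this assay. Nothing at hand gives a measured property of these compounds that would bear on this result.

The compounds shown leave open whether any substituent at this place on the ring can move the number beyond the scatter, since fluoro is the only one shown there, and a methoxy group, a trifluoromethyl group or an amine would test this with something larger than a single atom. They also leave open how far the number depends on the tert-butyl group on the other side of the shared core, which a longer chain or a carboxylic acid in that place would address.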